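Halogen Position Shift on the Benzyl Carboxylic Acid

The source may report more compounds than this note shows. Statements on the series, on what has been measured and on what is new or still open speak of the compounds shown alone.

Compound 3 `CC#CCn1c(N2CCC[C@@H](N)C2)cc(=O)n(Cc2cc(Br)cc(C(=O)O)c2)c1=O` stands where the numbers shown give no fixed point: in an assay on isolated protein for inhibition of Dipeptidyl peptidase 9 (Homo sapiens), read by fluorescence, with stated times of 15 min and 20 min (a lower number here means a stronger inhibitor, a higher number a weaker inhibitor), compound 3 returns only the limit > 100 nM, which is a limit of the assay and not a number. Compound 1 `CC#CCn1c(N2CCC[C@@H](N)C2)cc(=O)n(Cc2ccc(Cl)c(C(=O)O)c2)c1=O` sits at the same limit, giving > 100 nM in this assay. Compound 2 `CC#CCn1c(N2CCC[C@@H](N)C2)cc(=O)n(Cc2cccc(C(=O)O)c2F)c1=O` has no result, recorded as "not determined" (no result reported) in this assay. Going by the values given here, the one measured step, a step that the two limits leave unreadable from compound 1 to compound 3, cannot be read in size because the limit of > 100 nM in this assay, at which 2 of the 3 values shown sit, shows both of its ends resting at the limit. Compound 4 `CC#CCn1c(N2CCC[C@@H](N)C2)cc(=O)n(Cc2cc(C(=O)O)ccc2F)c1=O` carries the change (5-carboxy-2-fluorophenyl in place of 3-bromo-5-carboxyphenyl on a saturated chain carbon bound to an aromatic nitrogen). With no readable step bearing on this change, the step that the limit leaves unreadable from compound 3 to compound 4 is expected to be none beyond the scatter. Compound 4 is therefore estimated at 300 nM, between 100 nM and 3000 nM in this assay.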

Compound 4, half-maximal inhibitory concentration: > 100 nM
Compound 4: only a limit was reported; the forecaster's own chance of this, stated with the estimate: 75%; the middle value lies beyond the limit too.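

No step from compound 1 to compound 4 or from compound 3 to compound 4 can be read in this assay: the limit of > 100 nM in this assay, at which 3 of the 4 values shown sit.

The compounds shown leave open whether the different halogen-bearing carboxyphenyl groups of compound 1, compound 3 and compound 4 differ in inhibition at all.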